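Varying the ring on the aromatic nitrogen

The source may hold more compounds than are shown below. What is called first, only, known or untested is meant among the compounds shown, and "the series" means these compounds.

Compound 1 `Fc1cccc(-c2nc(Nc3ccccc3)c3cc(F)ccc3n2)c1` gives 47800 nM in a functional assay on MDA-MB-231 cells (Homo sapiens) for cytotoxicity, read by MTT assay, with a stated time of 48 h; a higher number here means a weaker inhibitor, a lower number a stronger inhibitor. Compound 2 `Fc1cccc(-c2nc(Nc3ccccc3F)c3cc(F)ccc3n2)c1` reaches only the limit > 50000 nM in this assay. Compound 3 `Fc1cccc(-c2nc(Nc3ccc(Br)cc3)c3cc(F)ccc3n2)c1` likewise reaches only the limit > 50000 nM in this assay, so compound 3 stands at the weak edge of what can be read, where the limit of > 50000 nM in this assay, at which 2 of the 3 values shown sit, applies. Compound 4 `Oc1cccc(Nc2nc(-c3cccc(F)c3)nc3ccc(F)cc23)c1` differs from compound 3 by 3-hydroxyphenyl in place of 4-bromophenyl on a nitrogen on an aromatic ring. The steps measured so far, an at least 1.0-fold higher number from compound 1 to compound 2 (0.01 log units; that floor lies within the scatter) and an at least 1.0-fold higher number from compound 1 to compound 3 (0.01 log units; that floor lies within the scatter), are floors within the scatter, and a step that the two limits leave unreadable from compound 2 to compound 3 has no readable size. For the measured compounds named here, no measured step involves a 3-hydroxyphenyl group, so nothing beyond the scatter is expected. For compound 4 the step is estimated as a number no higher from compound 3 to compound 4 (the limit leaves the size open). Compound 4 is expected near 50000 nM, between 20000 nM and 125000 nM, with another limit quite likely.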

Compound 4, half-maximal inhibitory concentration: > 50000 nM
Compound 4 was reported as a limit; the forecaster's own chance of this, stated with the estimate: 55%; the middle value lies on the limit itself.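

On the ring carried by the nitrogen, 3-hydroxyphenyl brings a hydrogen-bond donor that 4-bromophenyl lacks, yet in this assay compound 4 stands at the limit > 50000 nM and shows no readable gain. Adding a hydroxy group gives an at least 1.0-fold higher number from compound 1 to compound 4 (0.01 log units; that floor lies within the scatter), so this change adds nothing readable to the unsubstituted phenyl. The steps among compound 2, compound 3 and compound 4 cannot be read, because each end is a limit: the limit of > 50000 nM in this assay, at which 3 of the 4 values shown sit.

Going by these compounds, whether an amine, a carboxylic acid or a methoxy group on this ring brings a value clear of the limit stays open. Changes elsewhere on the shared core stay open too.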